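Cyclobutyl for cyclopropylmethyl on the amine nitrogen

The compounds below may be only part of what the source reports. "The series", "measured", "known", "first", "only" and "open" are said of these compounds alone.

Of the compounds shown here, three sharing one core have been measured in an ADME assay on liver (Mus musculus) for metabolic stability, read by LC-MS, using microsomes and NADPH; on this read-out higher numbers stand for a more stable compound and lower numbers for a less stable compound. There, compound 1 `CCN(Cc1ccc(OCCn2c(=O)ccn(C)c2=O)c(C)c1)C(CC(=O)O)c1ccc(Cl)cc1` gives 37%, compound 2 `CCCN(Cc1ccc(OCCn2c(=O)ccn(C)c2=O)c(C)c1)C(CC(=O)O)c1ccc(Cl)cc1` gives 23% and compound 3 `Cc1cc(CN(CC2CC2)C(CC(=O)O)c2ccc(Cl)cc2)ccc1OCCn1c(=O)ccn(C)c1=O` gives 24%. Compound 3 therefore stands level with compound 2, and both lie lower than compound 1.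

Compound 4 `Cc1cc(CN(C2CCC2)C(CC(=O)O)c2ccc(Cl)cc2)ccc1OCCn1c(=O)ccn(C)c1=O` has the same atoms as compound 3, joined differently: cyclobutyl in place of cyclopropylmethyl on an amine nitrogen, with cyclobutyl in place of cyclopropylmethyl on an amine nitrogen. The measured steps all concern the group on this nitrogen. Both a number 14 percentage points lower from compound 1 to compound 2 (beyond the scatter) and a number 13 percentage points lower from compound 1 to compound 3 (beyond the scatter) were modest, whereas a number 1 percentage points higher from compound 2 to compound 3 (within the scatter) stayed within the scatter. Going by the values given here, that last step is the closest guide, although no measured compound carries a ring directly on the nitrogen, so the range is kept wide. Resting on a number 1 percentage points higher from compound 2 to compound 3 (within the scatter), no step beyond the scatter is expected in this assay. The expected step is a number 1 percentage points higher from compound 3 to compound 4 (within the scatter). For compound 4 the estimated value is 25%, with an expected range from 12% to 40%.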

Compound 4, percent of the compound remaining: 22%
For compound 4 the middle estimate is 3 percentage points above the measured one; the measured number falls inside the stated range.
By their numbers in this assay, from the lowest: compounds 4, 2 and 3 (each within the scatter of the next); then compound 1.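

In this assay, setting a ring directly on the amine nitrogen gives a result that cannot be told apart from those of the open chain or the ring held one carbon away, with a number 2 percentage points lower from compound 3 to compound 4 (within the scatter) and a number 1 percentage points lower from compound 2 to compound 4 (within the scatter) both lying within the scatter. Against the ethyl group, cyclobutyl gives a number 15 percentage points lower from compound 1 to compound 4 (beyond the scatter) as a step beyond the scatter, so among the four groups shown on this nitrogen, ethyl alone stands apart. Nothing available gives a reason for these numbers.

As far as these compounds go, it remains open whether methyl or a bare amine hydrogen on this nitrogen would carry the read-out above that of ethyl. Also open, from the compounds shown here alone, is how cyclopropyl set directly on the nitrogen, or a chain carrying an ether oxygen or a hydroxyl group, would compare.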